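The compounds below may be only part of what the source reports. "The series", "measured", "known", "first", "only" and "open" are said of these compounds alone.

Compound 1 `COc1ccc(N2COc3ccc(C(=O)/C=C/c4ccccc4Cl)cc3C2)cc1` and compound 2 `COc1ccc(N2COc3ccc(C(=O)/C=C/c4cc(OC)c(OC)c(OC)c4)cc3C2)cc1` share a core that carries the chalcone and the 4-methoxyphenyl group; the difference between the two cores is not broken down here. In a functional assay on the whole organism (strain Wistar) for inhibition, with Rattus norvegicus as the target, read by paw edema, with a stated time of 3 h, at a dose of 20 mg/kg by the oral route (a lower number here means less inhibition, a higher number more inhibition at the dose given (going by the name of the read-out)), compound 1 gives 63.4% and compound 2 gives 62.2%. Compound 3 `Cc1ccc(N2COc3ccc(C(=O)/C=C/c4ccccc4Cl)cc3C2)cc1` is compound 1 with methyl in place of methoxy on an aromatic carbon; in this assay compound 3 gives 60.4%, and the step of a number 3 percentage points lower from compound 1 to compound 3 (within the scatter). Compound 4 `COc1cc(/C=C/C(=O)c2ccc3c(c2)CN(c2ccc(C)cc2)CO3)cc(OC)c1OC` stands to compound 2 as compound 3 stands to compound 1: methyl in place of methoxy on an aromatic carbon, the same kind of change at a place described in the same words. The matching step a number 3 percentage points lower from compound 1 to compound 3 (within the scatter) stayed within the scatter. On that ground the step from compound 2 to compound 4 is expected to be small as well, a number 3.2 percentage points lower from compound 2 to compound 4 (within the scatter). Compound 4 is therefore estimated at 59%, with the expected range 50% to 68%.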

Compound 4, a percentage reported as inhibition, in the whole organism at one dose (the size of the read-out at that dose, not a potency): 56.5%
Estimate against measurement, compound 4: 2.5 percentage points above; low and high end bracket the measured number.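

In this assay the change from 4-methoxyphenyl to 4-methylphenyl gives a number 5.7 percentage points lower from compound 2 to compound 4 (within the scatter), and the two steps on the two cores do not differ: the same change on two cores in this assay, a number 3 percentage points lower (within the scatter) from compound 1 to compound 3 and a number 5.7 percentage points lower (within the scatter) from compound 2 to compound 4, 2.7 percentage points apart, within the scatter of two such steps.

Within these two pairs, then, the change carries from the core of compound 1 to the core of compound 2 without a visible dependence on the core. It does not show that the change itself alters inhibition at this dose: both steps lie within the scatter, and two pairs speak for these two cores only.

Open, as far as these compounds go, is how an amine, a carboxylic acid or a longer chain at the same place would read in this assay. Also open, from the compounds shown here alone, is whether the change carries to cores beyond these two.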